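The source may report more compounds than this note shows. Statements on the series, on what has been measured and on what is new or still open speak of the compounds shown alone.

For the measured compounds named here, in a functional assay on MKN-45 cells (Homo sapiens) for cytotoxicity, read by MTT assay, with a stated time of 72 h (on this read-out higher numbers stand for weaker inhibition and lower numbers for stronger inhibition), compound 2 `COc1cc2c(Oc3ccc(NC(=O)c4cc(-c5ccc(Cl)c(Cl)c5)nc5ccccc45)cc3F)ccnc2cc1OCCCN1CCCC1` gives 170 nM, the lower of the two numbers measured so far. Compound 1 `COc1cccc(-c2cc(C(=O)Nc3ccc(Oc4ccnc5cc(OCCCN6CCCCC6)c(OC)cc45)c(F)c3)c3ccccc3n2)c1` gives 360 nM in this assay, a higher number that lies beyond the scatter. Compound 3 `COc1cccc(-c2cc(C(=O)Nc3ccc(Oc4ccnc5cc(OCCCN6CCCC6)c(OC)cc45)c(F)c3)c3ccccc3n2)c1` is not yet measured; it differs from compound 2 in one place: 3-methoxyphenyl in place of 3,4-dichlorophenyl on an aromatic carbon. Compound 1 carries the same 3-methoxyphenyl, so a step toward a weaker result is expected from compound 2 to compound 3, of size a 1.9-fold higher number from compound 2 to compound 3 (0.27 log units; within the scatter) in this assay. Compound 3 is therefore estimated at 320 nM, somewhere between 140 nM and 750 nM.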

Compound 3, half-maximal inhibitory concentration: 430 nM
For compound 3 the middle estimate is 1.3-fold (0.13 log units) below the measured one; the measured number falls inside the stated range.
By their numbers in this assay, from the lowest: compound 2; then compounds 1 and 3 (each within the scatter of the next).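

In this assay, exchanging the aryl group on the aromatic carbon next to the ring nitrogen now has a direct reading: a 2.5-fold higher number from compound 2 to compound 3 (0.40 log units; beyond the scatter) is a modest weakening with 3-methoxyphenyl in place of 3,4-dichlorophenyl. On the saturated chain, pyrrolidin-1-yl in place of piperidin-1-yl gives a 1.2-fold higher number from compound 1 to compound 3 (0.08 log units; within the scatter), so these two rings cannot be told apart here. No measured evidence explains either result. From the compounds shown here alone, whether a phenyl carrying a single chlorine would read closer to compound 2 or compound 3 remains open. So does the effect of a morpholine ring on the same chain.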